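The source may hold more compounds than are shown below. What is called first, only, known or untested is meant among the compounds shown, and "the series" means these compounds.

Compound 1: `Nc1nc(-c2ccc(Br)cc2)cn1/N=C/c1cc2ccccc2nc1Cl`, 23900 nM
Compound 2: `Cc1ccc(-c2cn(/N=C/c3cc4cc(C)ccc4nc3Cl)c(N)n2)cc1`, 25200 nM
Compound 3: `Cc1ccc2nc(Cl)c(/C=N/n3cc(-c4ccc(Br)cc4)nc3N)cc2c1`, 39300 nM

All three were tested in a functional assay on DLD-1 cells (Homo sapiens) for cytotoxicity, read by MTT assay, with a stated time of 48 h; a higher number here means a weaker inhibitor, a lower number a stronger inhibitor. Compound 3 has the largest number of the three, but this tells little: the step of a 1.6-fold higher number from compound 1 to compound 3 (0.22 log units; within the scatter) and the step of a 1.6-fold higher number from compound 2 to compound 3 (0.19 log units; within the scatter) both lie within the scatter, so the three compounds cannot be told apart on these numbers.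

Compound 4 is `Cc1ccc2nc(Cl)c(/C=N/n3cc(-c4cccs4)nc3N)cc2c1`. It differs from compound 3 in one place: thiophen-2-yl in place of 4-bromophenyl on an aromatic carbon. Within the data shown here, two measured steps bear on this change, though only loosely. The step of a 1.6-fold higher number from compound 2 to compound 3 (0.19 log units; within the scatter) swaps one group on the same aromatic ring that is now replaced, and the step of a 1.6-fold higher number from compound 1 to compound 3 (0.22 log units; within the scatter) alters a group elsewhere on the shared core; neither moved the number beyond the scatter. Among the measured compounds shown here, no measured pair replaces the whole 4-bromophenyl ring by a smaller heteroaromatic ring, so the change in compound 4 is larger than anything that has been tried. Given that the two small changes left this assay essentially unmoved, the expectation is a step of a 1.3-fold lower number from compound 3 to compound 4 (0.12 log units; within the scatter), with no clear direction beyond the scatter. Compound 4 is therefore estimated at 30000 nM, within the range 12000 nM to 80000 nM.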

Compound 4, half-maximal inhibitory concentration: 8990 nM
Beside the measured number, compound 4's estimate is 3.3-fold (0.52 log units) above it, outside the stated range (below it).
By their numbers in this assay, from the lowest: compound 4; then compounds 1, 2 and 3 (each within the scatter of the next).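

In this assay the ring on the aromatic carbon of the five-membered aromatic ring with 2 nitrogen turns out to matter: thiophen-2-yl in place of 4-bromophenyl gives a modest step beyond the scatter (a 4.4-fold lower number from compound 3 to compound 4 (0.64 log units; beyond the scatter)), and thiophen-2-yl in place of 4-methylphenyl gives another (a 2.8-fold lower number from compound 2 to compound 4 (0.45 log units; beyond the scatter)). The earlier exchange of a methyl for a bromo on that phenyl ring stayed within the scatter (a 1.6-fold higher number from compound 2 to compound 3 (0.19 log units; within the scatter)), so at this position replacing the whole ring moved the number where changing its substituent did not, although this rests on compound 4 alone. No measurement at hand gives a reason for these steps.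

The compounds shown leave open whether the lower number follows from the sulfur-bearing ring itself or from the loss of the substituted phenyl ring, a question that furan-2-yl, pyridin-2-yl or unsubstituted phenyl at the same position would bear on. They also leave open whether thiophen-2-yl gives a similar step on the core of compound 1, and whether an amine or a longer chain at this position would move the number further.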